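Azetidine oxadiazole amides: swapping the aryl amide for a piperidine urea

The compounds below may be only part of what the source reports. "The series", "measured", "known", "first", "only" and "open" are said of these compounds alone.

Within the data shown here, compound 2 `O=C(c1ccccc1F)N1CC(c2nc(-c3cccc(Cl)c3)no2)C1` stands as the lower of the two numbers so far in an assay on HEK293 cells for negative allosteric modulation of metabotropic glutamate receptor 5 (Homo sapiens), read by FLIPR (a higher number here means a weaker inhibitor, a lower number a stronger inhibitor), where compound 2 gives 670 nM. Compound 1 `O=C(c1ccc(F)cc1)N1CC(c2nc(-c3cccc(Cl)c3)no2)C1` gives 4000 nM in this assay, and the change a 6.0-fold lower number from compound 1 to compound 2 (0.78 log units; beyond the scatter) moves only the fluorine on the phenyl ring. Compound 3 `COC1CCN(C(=O)N2CC(c3nc(-c4cccc(Cl)c4)no3)C2)CC1` differs from compound 2 by 4-methoxypiperidin-1-yl in place of 2-fluorophenyl on a carbonyl carbon, so an aromatic ring gives way to a saturated ring carrying one hydrogen-bond acceptor on the carbonyl carbon whose other neighbour is the amide-type nitrogen in a ring. Among the measured compounds shown here, no measured step covers such a replacement; the single step from compound 1 to compound 2 bears on it only in showing that this carbonyl substituent is sensitive to change. A weaker number is therefore expected for compound 3, with wide uncertainty, with the step of a 4.5-fold higher number from compound 2 to compound 3 (0.65 log units; beyond the scatter) taken as the estimate. Compound 3 is expected to give 3000 nM in this assay, within the range 600 nM to 15000 nM.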

Compound 3, half-maximal inhibitory concentration: > 10000 nM
Compound 3: no number, only a limit; the forecaster's own chance of this, stated with the estimate: 20%; at least 3.3-fold (0.52 log units) between middle value and limit.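

For compound 3 the reading in this assay is a limit of the assay and not a number: the limit of > 10000 nM in this assay, at which 1 of the 3 values shown sits. With that limit, 4-methoxypiperidin-1-yl on the carbonyl carbon falls short of both aryl groups, giving an at least 14-fold higher number from compound 2 to compound 3 (1.17 log units; beyond the scatter) against the 2-fluorophenyl amide and an at least 2.5-fold higher number from compound 1 to compound 3 (0.39 log units; beyond the scatter) against the 4-fluorophenyl amide. The earlier pair showed only that moving a fluorine on the phenyl ring changes the number, whereas this result shows that the saturated ring tested here is a poorer substituent at this position than either aryl group, by a margin that the limit leaves without an upper bound.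

The change swaps the ring and adds the methoxy group in a single step, so their shares cannot be told apart. From the compounds shown here alone, whether a plain piperidin-1-yl, a morpholin-4-yl or a pyridyl group on this carbonyl carbon would do better remains open.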